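Piperazine substituent variation on the sulfonamide series

This account rests on a few compounds, and the source may have more. Where it says the series, first, only, none or still open, it means among the compounds named here.

Measured compounds: compound 1 `CCCn1c(=O)[nH]c2nc(-c3ccc(S(=O)(=O)N4CCN(c5ccccc5C)CC4)cc3)[nH]c2c1=O` gives 0.432 nM in an assay on CHO cells for displacement of a labelled ligand from adenosine receptor A2b (Homo sapiens), read by scintillation counting, with a stated time of 75 min, in the presence of a further agent that is not named here; a lower number here means a stronger inhibitor, a higher number a weaker inhibitor; compound 2 `CCCn1c(=O)[nH]c2nc(-c3ccc(S(=O)(=O)N4CCN(Cc5cccc(Br)c5)CC4)cc3)[nH]c2c1=O` gives 0.148 nM; compound 3 `CCCn1c(=O)[nH]c2nc(-c3ccc(S(=O)(=O)N4CCN(c5cccc(Br)c5)CC4)cc3)[nH]c2c1=O` gives 0.234 nM.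

Compound 3 sits second highest of the three numbers. Its nearest neighbour is compound 2, with a 1.6-fold higher number from compound 2 to compound 3 (0.20 log units; within the scatter), and its furthest is compound 1, with a 1.8-fold lower number from compound 1 to compound 3 (0.27 log units; within the scatter); neither gap exceeds the scatter, so no order among the three is claimed. Going by the values given here, the only step that exceeds the scatter is a 2.9-fold lower number from compound 1 to compound 2 (0.47 log units; beyond the scatter).

The next compound, compound 4 `CCCn1c(=O)[nH]c2nc(-c3ccc(S(=O)(=O)N4CCN(C(C)c5ccccc5)CC4)cc3)[nH]c2c1=O`, is still to be measured. It differs from compound 3 by 1-phenylethyl in place of 3-bromophenyl on an amine nitrogen in a ring. Among the compounds with values here, the step that bears most directly on this change is the one between compound 2 and compound 3, which replaces a benzyl-type group on the ring nitrogen by a phenyl group and gives a 1.6-fold higher number from compound 2 to compound 3 (0.20 log units; within the scatter), within the scatter. Within the data shown here, no measured step covers the extra methyl on the linking carbon of the 1-phenylethyl group, so nothing beyond that comparison can be drawn. The expectation is therefore a step no larger than the scatter in either direction, written as a 1.2-fold lower number from compound 3 to compound 4 (0.07 log units; within the scatter). Compound 4 is estimated at 0.2 nM, with a range from 0.07 nM to 0.6 nM.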

Compound 4, inhibition constant: 8.34 nM
Compound 4: middle estimate off by 42-fold (1.62 log units), on the low side, outside the stated range (above it).
By their numbers in this assay, from the lowest: compounds 2, 3 and 1 (each within the scatter of the next, the first and the last beyond it); then compound 4.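

In this assay the substituent on the amine nitrogen in the ring proves not to be a free choice: 3-bromophenyl, 3-bromobenzyl and 2-methylphenyl stay close together, whereas 1-phenylethyl gives a large loss against each of them (a 36-fold higher number from compound 3 to compound 4 (1.55 log units; beyond the scatter); a 56-fold higher number from compound 2 to compound 4 (1.75 log units; beyond the scatter); a 19-fold higher number from compound 1 to compound 4 (1.29 log units; beyond the scatter)). The largest earlier step in the series was modest by comparison (a 2.9-fold lower number from compound 1 to compound 2 (0.47 log units; beyond the scatter)), so the three earlier compounds gave no sign of how much this position can matter. Compared with 3-bromobenzyl, 1-phenylethyl carries an extra methyl on the linking carbon and has no bromine, and no measurement available here accounts for the loss.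

The compounds shown cannot separate those two differences, so it remains open whether the loss follows the methyl, the missing bromine or the two together. Unsubstituted benzyl and 1-(3-bromophenyl)ethyl on the same nitrogen would divide the question, and a longer chain such as 2-phenylethyl would show whether the aromatic ring tolerates being placed further from the ring nitrogen.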